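A few compounds are considered here, and "the series" means these few. Any claim that something is new, unique, unknown or untested is made for them only; others in the source may bear on it.

Measured in a functional assay on DU-145 cells (Homo sapiens) for cytotoxicity, read by MTT assay, with a stated time of 72 h; a lower number here means a stronger inhibitor, a higher number a weaker inhibitor:
compound 1 `CCCC(Nc1cncc(-c2ccc(O)c(OC)c2)n1)c1ccc(Cl)cc1`: 10000 nM
compound 2 `CCCC(Nc1cncc(-c2ccc(O)c(OC)c2)n1)c1ccc(F)cc1`: 4000 nM
compound 3 `CCCC(Nc1cncc(-c2ccc(O)c(OC)c2)n1)c1cccc(Cl)c1`: 600 nM

Compound 4 `CCCC(Nc1cncc(-c2ccc(O)c(OC)c2)n1)c1cccc(F)c1` is not yet measured. It differs from compound 3 by fluoro in place of chloro on an aromatic carbon. The same kind of change occurs once more among these compounds, from compound 1 to compound 2, (fluoro in place of chloro on an aromatic carbon), where it gave a 2.5-fold lower number from compound 1 to compound 2 (0.40 log units; beyond the scatter). The two places are not identical: in compound 1 the exchanged group sits para to a large group, in compound 3 meta to a large group. The cores themselves differ by 3-chlorophenyl in place of 4-chlorophenyl on a saturated chain carbon bound to a nitrogen on an aromatic ring and a saturated chain carbon, a difference that gave a 17-fold lower number from compound 1 to compound 3 (1.22 log units; beyond the scatter). Carrying the earlier step over, the step from compound 3 to compound 4 is expected to be a 2.0-fold lower number from compound 3 to compound 4 (0.30 log units; within the scatter), resting on that single pair only. Compound 4 is estimated at 300 nM, expected to fall between 100 nM and 1000 nM.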

Compound 4, half-maximal inhibitory concentration: 300 nM
For compound 4 middle estimate and measured number coincide at the digits printed, within the range that was stated.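

In this assay, fluoro in place of chloro gives steps of matching size on the two cores: the same change on two cores in this assay, a 2.5-fold lower number (0.40 log units; beyond the scatter) from compound 1 to compound 2 and a 2.0-fold lower number (0.30 log units; within the scatter) from compound 3 to compound 4, 1.3-fold (0.10 log units) apart, within the scatter of two such steps
Taken alone, a 2.0-fold lower number from compound 3 to compound 4 (0.30 log units; within the scatter) cannot be told apart from repeat scatter, and the larger steps go with the change of ring substitution, with a 13-fold lower number from compound 2 to compound 4 (1.12 log units; beyond the scatter) for 3-fluorophenyl in place of 4-fluorophenyl and a 33-fold lower number from compound 1 to compound 4 (1.52 log units; beyond the scatter) for 3-fluorophenyl in place of 4-chlorophenyl. Two pairs support carrying this exchange between these two cores only and do not establish it as a rule for other cores in the series.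

Still open, on these data alone, is how a bromo or trifluoromethyl group would read at the same ring place. As far as these compounds go, the effect of a longer chain on the saturated carbon also remains open.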